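Thioamide Azepane in Place of the Thiomorpholine Amide

The source may report more compounds than this note shows. Statements on the series, on what has been measured and on what is new or still open speak of the compounds shown alone.

All members of this small set share the core shown by compound 1 `CCCCc1nc(CCC)c(CCC(=O)OCC)c(=O)n1Cc1ccc(-c2ccccc2-c2nnn[nH]2)cc1`, for which an in vivo functional assay on the whole organism for inhibition, with Rattus norvegicus as the target (a lower number here means that less compound is needed, a higher number that more compound is needed for the effect), gives "not determined" (no result reported). Compound 2 `CCCCc1nc(C)c(CC(=O)N2CCC[C@H]2C(N)=O)c(=O)n1Cc1ccc(-c2ccccc2-c2nnn[nH]2)cc1` gives 0.023 mg/kg in this assay, and compound 3 `CCCCc1nc(C)c(CC(=O)N2CCSCC2)c(=O)n1Cc1ccc(-c2ccccc2-c2nnn[nH]2)cc1` gives 0.038 mg/kg. Among the two numbers, compound 3 stands highest, its nearest neighbour being compound 2, separated by a 1.7-fold higher number from compound 2 to compound 3 (0.22 log units; within the scatter), a step that stays within the scatter; compound 1 contributes no number.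

Compound 4 `CCCCc1nc(C)c(CC(=S)N2CCCCCC2)c(=O)n1Cc1ccc(-c2ccccc2-c2nnn[nH]2)cc1` differs from compound 3 in one place: a group of 9 heavy atoms (7 carbon, 1 nitrogen, 1 sulfur; one seven-membered non-aromatic ring with 1 hetero atom) in place of a group of 8 heavy atoms (5 carbon, 1 nitrogen, 1 oxygen, 1 sulfur; one six-membered non-aromatic ring with 2 hetero atoms), on a saturated chain carbon bound to an aromatic carbon. Within the data shown here, only one measured step touches this position, a 1.7-fold higher number from compound 2 to compound 3 (0.22 log units; within the scatter), and it remained within the scatter when one ring amine replaced another. Among the measured compounds shown here, the change to compound 4 goes further, replacing the carbonyl oxygen with sulfur as well as widening the ring, and no measured pair in this set speaks to that. With nothing pointing in either direction, compound 4 is expected to land at 0.04 mg/kg, between 0.012 mg/kg and 0.13 mg/kg. The expected step is a 1.1-fold higher number from compound 3 to compound 4 (0.02 log units; within the scatter), nothing beyond the scatter.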

Compound 4, dose for half-maximal effect: 0.034 mg/kg
Compound 4: the middle estimate sits 1.2-fold (0.07 log units) above what was measured; the measured number falls inside the stated range.
By their numbers in this assay, from the lowest: compounds 2, 4 and 3 (each within the scatter of the next).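

The position on a saturated chain carbon bound to an aromatic carbon now proves to accept a larger change than the exchange of one ring amine for another. In this assay, the seven-membered ring thioamide in place of (thiomorpholin-4-yl)carbonyl gives a 1.1-fold lower number from compound 3 to compound 4 (0.05 log units; within the scatter), and the comparison with the 2-carbamoylpyrrolidine amide gives a 1.5-fold higher number from compound 2 to compound 4 (0.17 log units; within the scatter), so the sulfur in place of the carbonyl oxygen and the wider ring together leave all three numbers within the scatter of one another. Ring size and the sulfur change in the same step, so neither can be read alone, and nothing on hand explains why the numbers stay so close. Going by these compounds, what the plain azepane amide with its carbonyl oxygen would give remains open. Also open, on these data alone, is whether an open-chain diethylamine amide or a carboxylic acid at this position would stay in the same range.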